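A few compounds are considered here, and "the series" means these few. Any claim that something is new, unique, unknown or untested is made for them only; others in the source may bear on it.

Going by the values given here, compound 2 `COc1c(OCCCCN2CCN(C)CC2)cc(O)c2c(=O)cc(-c3ccc(F)cc3)oc12` gives 3860 nM in a functional assay on MCF7 cells (Homo sapiens) for cytotoxicity, read by MTT assay, with a stated time of 72 h (on this read-out higher numbers stand for weaker inhibition and lower numbers for stronger inhibition), the lowest of the two numbers so far, though the nearest, compound 1 `COc1ccc(-c2cc(=O)c3c(O)cc(OCCCCN4CCN(C)CC4)c(OC)c3o2)cc1` at 3980 nM, sits within the scatter of it. Among the compounds with values here, the one step among the measured pair, a 1.0-fold lower number from compound 1 to compound 2 (0.01 log units; within the scatter), swaps fluoro for methoxy on an aromatic carbon and does not touch the change now in question. Compound 3 `COc1c(OCCCCN2CCN(C)CC2)cc(O)c2c(=O)cc(-c3ccc(F)cc3Br)oc12` differs from compound 2 by bromo in place of hydrogen on an aromatic carbon, that is, 4-fluorophenyl becomes 2-bromo-4-fluorophenyl. Within the data shown here, no measured step adds a bromo to this ring, so the account rests on the narrow spread of the two known values alone. On that basis compound 3 is expected to land close to compound 2, with a step of a 1.2-fold lower number from compound 2 to compound 3 (0.08 log units; within the scatter) that could fall either way within the scatter. The estimate for compound 3 is 3200 nM, with a range from 1000 nM to 10000 nM in this assay.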

Compound 3, half-maximal inhibitory concentration: 3090 nM
The estimate for compound 3 lay 1.0-fold (0.02 log units) above the measured number; the range from low to high includes it.
By their numbers in this assay, from the lowest: compounds 3, 2 and 1 (each within the scatter of the next).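

In this assay the new position, on an aromatic carbon ortho to a large group and meta to the fluoro group, takes a bromo group with no change that can be told from the scatter, as a 1.2-fold lower number from compound 2 to compound 3 (0.10 log units; within the scatter) shows. The wider exchange of the whole aryl group, seen in a 1.3-fold lower number from compound 1 to compound 3 (0.11 log units; within the scatter), is also within the scatter, so neither the first substituent on this ring nor this added bromo has yet separated any of the three compounds. Nothing available explains why the number stays put, and no outside measurement bears on this result.

On these data alone, whether a smaller chloro group or a methyl group at this place would read the same remains open. As far as these compounds go, it is also open whether an amine or a carboxylic acid on this ring would move the number beyond the scatter.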